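The source may hold more compounds than are shown below. What is called first, only, known or untested is meant among the compounds shown, and "the series" means these compounds.

Compound 1, `COc1cc(N(CC2CC2)c2ccc(Cl)c3ccccc23)cnc1C(=O)[C@H]1C[C@@H]1C(=O)O`, gives 1.41 nM in an assay for inhibition of leukotriene C4 synthase (Homo sapiens), read by LC-MS, with stated times of 15 min and 30 min; a lower number here means a stronger inhibitor, a higher number a weaker inhibitor.
Compound 2, `COc1nc(C(=O)[C@@H]2C[C@H]2C(=O)O)ncc1N(CC1CC1)c1ccc(Cl)c2ccccc12`, gives 15.5 nM in this assay.
Compound 3, `COc1cc(N(CC(C)C)c2cccc(C(F)(F)F)c2)cnc1C(=O)[C@H]1C[C@@H]1C(=O)O`, gives 4.74 nM in this assay.

Of these three numbers, compound 3 stands second highest: compound 1 shows a lower number and compound 2 a higher one, and both of those gaps lie beyond the usual scatter.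

Compound 4, `COc1cc(N(Cc2ccc(F)cc2)c2cccc(C(F)(F)F)c2)cnc1C(=O)[C@H]1C[C@@H]1C(=O)O`, has not yet been measured. Its structure differs from compound 3 in one place: 4-fluorophenyl in place of isopropyl on a saturated chain carbon bound to a nitrogen on an aromatic ring. For the measured compounds named here, no measured pair shows this kind of exchange, so there is nothing to set a direction from. The expected step from compound 3 to compound 4 is therefore a 1.1-fold higher number from compound 3 to compound 4 (0.02 log units; within the scatter), no change beyond the scatter. For compound 4 the estimated value is 5 nM, with a range from 1.5 nM to 20 nM.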

Compound 4, half-maximal inhibitory concentration in the leukotriene C4 synthase assay: 13.5 nM
Beside the measured number, compound 4's estimate is 2.7-fold (0.43 log units) below it, and the stated range covers the measured number.
By their numbers in the leukotriene C4 synthase assay, from the lowest: compound 1; then compound 3; then compounds 4 and 2 (each within the scatter of the next).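

The first exchange seen at this place, on a saturated chain carbon bound to a nitrogen on an aromatic ring, shows that the group there matters: in the leukotriene C4 synthase assay, going from isobutyl to 4-fluorobenzyl gives a 2.8-fold higher number from compound 3 to compound 4 (0.45 log units; beyond the scatter), a modest loss that still leaves compound 4 an inhibitor at 13.5 nM. In a physicochemical assay for lipophilicity, read by LC-MS, in phosphate buffer, measured as octanol-water partition, at pH 7.4 (on this read-out higher numbers stand for higher lipophilicity and lower numbers for lower lipophilicity), compound 3 gives 1.6 and compound 4 gives 1.9; the same change gives a number 0.30 log units higher from compound 3 to compound 4 (within the scatter), so that read-out does not separate the pair. Nothing shown explains the weakening.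

As far as these compounds go, whether the loss follows the aromatic ring or its fluorine remains open, and so does how an unsubstituted benzyl group or a longer chain carrying an amine would read here.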